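This account rests on a few compounds, and the source may have more. Where it says the series, first, only, none or still open, it means among the compounds named here.

In a functional assay on NALM-6 cells (Homo sapiens) for cytotoxicity, with a stated time of 72 h (on this read-out lower numbers stand for an effect already at smaller amounts and higher numbers for an effect only at larger amounts of compound), compound 1 `C=C[C@@](C)(/C=C/c1ccc(O)c(/C=C/C(=O)OCC)c1)CCC=C(C)C` gives 20900 nM. Compound 2 `C=C[C@@](C)(/C=C/c1ccc(O)c(/C=C/C(N)=O)c1)CCC=C(C)C` gives only a limit, > 43400 nM, and not a number. Compound 2 therefore stands at the limit of > 43400 nM in this assay, at which 1 of the 2 values shown sits. Compound 3 `C=C[C@@](C)(/C=C/c1ccc(O)c(/C=C/c2ccc(Cl)cc2)c1)CCC=C(C)C` is reached by a larger change: 4-chlorophenyl in place of carbamoyl on a double-bonded chain carbon bound to a double-bonded chain carbon, with 4-chlorophenyl in place of carbamoyl on a double-bonded chain carbon bound to a double-bonded chain carbon. Within the data shown here, one measured step bears on this, an at least 2.0-fold higher number from compound 1 to compound 2 (0.31 log units; beyond the scatter). That step was at least modest and shows that the group at the end of this chain can shift the number, although neither compound carries the new ring. Compound 3 loses the carbamoyl group of compound 2, so a lower number is expected, in the region of compound 1 at 20900 nM. The expected change is an at least 3.3-fold lower number from compound 2 to compound 3 (0.52 log units; beyond the scatter), and its size is uncertain. For compound 3, the estimated value is 13000 nM, with an expected range of 4000 nM to 40000 nM.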

Compound 3, half-maximal effective concentration: > 43400 nM
Compound 3 gave a limit, no number; the forecaster's own chance of this, stated with the estimate: 20%; at least 3.3-fold (0.52 log units) between middle value and limit.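

In this assay, 4-chlorophenyl in place of ethoxycarbonyl on a double-bonded chain carbon bound to a double-bonded chain carbon gives an at least 2.0-fold higher number from compound 1 to compound 3 (0.31 log units; beyond the scatter). So the loss seen with the amide is not peculiar to that group: a large aromatic ring, with no hydrogen-bond donor or acceptor, does not keep the number of compound 1 either. Compound 2 and compound 3 each carry a limit and not a number, and the step between them cannot be read: the limit of > 43400 nM in this assay, at which 2 of the 3 values shown sit.

Among these compounds, compound 1, at 20900 nM, remains the only true number at this place, and how far the number could fall here stays open. Going by these compounds, how a carboxylic acid or a methyl ester would read at this place is also open, as is any real difference between compound 2 and compound 3.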